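Swapping the aryl substituent on the ketone side of the core

The source may hold more compounds than are shown below. What is called first, only, known or untested is meant among the compounds shown, and "the series" means these compounds.

Three close analogues share one core and differ only in the ring attached to the carbonyl carbon. Compound 1 `COc1ccc(/C=C/c2cc(OC)cc(OC)c2/C=C/C(=O)c2cccc(Br)c2)cc1` carries 3-bromophenyl there and in a functional assay on HepG2 cells (Homo sapiens) for antiproliferative activity, read by MTT assay, with a stated time of 48 h (on this read-out lower numbers stand for stronger inhibition and higher numbers for weaker inhibition), compound 1 gives 13 ug/mL. Compound 2 `CCCC(C)Oc1ccc(C(=O)/C=C/c2c(/C=C/c3ccc(OC)cc3)cc(OC)cc2OC)cc1` carries 4-(1-methylbutoxy)phenyl and gives 11.1 ug/mL. Compound 3 `COc1ccc(/C=C/c2cc(OC)cc(OC)c2/C=C/C(=O)c2ccc(F)cc2)cc1` carries 4-fluorophenyl and gives 12.2 ug/mL. Compound 2 shows the lowest of the three numbers, yet every gap is within the scatter: a 1.2-fold lower number from compound 1 to compound 2 (0.07 log units; within the scatter), a 1.1-fold lower number from compound 1 to compound 3 (0.03 log units; within the scatter) and a 1.1-fold higher number from compound 2 to compound 3 (0.04 log units; within the scatter), so none of the three can be called the strongest.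

Compound 4 `CCN(CC)c1ccc(C(=O)/C=C/c2c(/C=C/c3ccc(OC)cc3)cc(OC)cc2OC)cc1` has not been measured. It differs from compound 2 in one place: diethylamino in place of 1-methylbutoxy on an aromatic carbon. All three measured steps change this same ring, and none moved the number beyond the scatter, so the expectation for compound 4 is a step of about a 1.0-fold lower number from compound 2 to compound 4 (0.00 log units; within the scatter), that is, no change beyond the scatter. On this basis compound 4 is estimated at 11 ug/mL, with a likely range from 5 ug/mL to 25 ug/mL.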

Compound 4, half-maximal inhibitory concentration: 6.3 ug/mL
Compound 4: the middle estimate sits 1.7-fold (0.24 log units) above what was measured; measured number inside the range.
By their numbers in this assay, from the lowest: compounds 4, 2, 3 and 1 (each within the scatter of the next, the first and the last beyond it).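

Until compound 4, no change to the ring on the carbonyl carbon had given a step beyond the scatter. In this assay, 4-(diethylamino)phenyl in place of 3-bromophenyl gives the first such step, though a modest one (a 2.1-fold lower number from compound 1 to compound 4 (0.31 log units; beyond the scatter)), while diethylamino cannot be separated from 1-methylbutoxy (a 1.8-fold lower number from compound 2 to compound 4 (0.25 log units; within the scatter)) or from fluoro (a 1.9-fold lower number from compound 3 to compound 4 (0.29 log units; within the scatter)), as both of these steps stay within the scatter. Among these compounds, nothing available shows what lies behind the one step that does pass the scatter.

The compounds shown leave open whether the nitrogen of diethylamino matters or whether the ethyl chains do. A dimethylamino group, a plain amino group or a piperidine ring at this same place would help to separate the two.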